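This account rests on a few compounds, and the source may have more. Where it says the series, first, only, none or still open, it means among the compounds named here.

Of the compounds shown here, three sharing a core have been measured in a functional assay on DU-145 cells (Homo sapiens) for antiproliferative activity, read by propidium iodide staining, with a stated time of 96 h; on this read-out higher numbers stand for weaker inhibition and lower numbers for stronger inhibition. Compound 1 `CC(O)(CSc1ccc(S(F)(F)(F)(F)F)cc1)C(=O)Nc1ccc(C#N)c(C(F)(F)F)c1` gives 27900 nM, compound 2 `CC(O)(CSc1ccc(S(F)(F)(F)(F)F)cc1)C(=O)Nc1ccc(C#N)cc1C(F)(F)F` gives 17700 nM, and compound 3 `CC(O)(CSc1ccc(S(F)(F)(F)(F)F)cc1)C(=O)Nc1ccc(S(F)(F)(F)(F)F)cc1` gives 22300 nM. Compound 3 therefore stands within the usual scatter of both compound 1 and compound 2, and all three numbers form a single group.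

The next compound to be tested is compound 4 `CC(O)(CSc1ccc(F)cc1)C(=O)Nc1ccc(S(F)(F)(F)(F)F)cc1`. Its difference from compound 3 is one fluorine atom in place of a group of 6 heavy atoms (5 fluorine, 1 sulfur; no ring), on an aromatic carbon. The exchange takes place on an aromatic carbon of a six-membered aromatic ring of carbon only, para to a large group, and the rest of the structure stays the same.

Among the measured compounds shown here, no measured pair shows this exchange, so the data give no direct guide to its size or direction. The only support is indirect: compound 1 at 27900 nM and compound 2 at 17700 nM differ from compound 3 elsewhere in the structure, yet remain within the scatter of it. On that basis, no change beyond the scatter is expected in this assay, though the uncertainty is wide. The expected step, a 1.3-fold higher number from compound 3 to compound 4 (0.13 log units; within the scatter), is small and has no firmly expected direction. Compound 4 is estimated at 30000 nM, with an expected range from 13000 nM to 65000 nM.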

Compound 4, half-maximal inhibitory concentration: 25400 nM
Estimate against measurement, compound 4: 1.2-fold (0.07 log units) above; measured number inside the range.
By their numbers in this assay, from the lowest: compounds 2, 3, 4 and 1 (each within the scatter of the next).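

In this assay, among the compounds shown here, the first measured exchange at this position, an aromatic carbon of a six-membered aromatic ring of carbon only, para to a large group, gives a 1.1-fold higher number from compound 3 to compound 4 (0.06 log units; within the scatter) when one fluorine atom replaces the group of 6 heavy atoms. Compounds 1, 2 and 3 all carry that group here, so they could say nothing about this position, whereas this pair shows that a far smaller fluoro group leaves the number within the scatter. The data shown offer no measurement that would explain this result.

As far as these compounds go, it remains open whether any other group at this position, such as an amine, a carboxylic acid or a longer chain, would move the number beyond the scatter, since the two groups compared here are both without hydrogen-bond donors or acceptors and carry no net charge. From the compounds shown here alone, it is also open whether the same exchange would stay as small on the nitrile- and trifluoromethyl-bearing structures of compound 1 and compound 2.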